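Exchanging One Aryl Urea Group for Another

The compounds below may be only part of what the source reports. "The series", "measured", "known", "first", "only" and "open" are said of these compounds alone.

Measured so far:
- compound 1, `O=C(Nc1cccc(-n2cc(-c3ccncc3)c(-c3ccc(Cl)c(O)c3)n2)c1)Nc1cccc(C(F)(F)F)c1`: 962 nM
- compound 2, `COc1cc(-c2nn(-c3cccc(NC(=O)Nc4ccc(Cl)c(Cl)c4)c3)cc2-c2ccncc2)ccc1Cl`: 691 nM

Of the compounds shown here, two have been tested in a functional assay on SF-295 cells (Homo sapiens) for inhibition, read by sulforhodamine B assay, with a stated time of 48 h; on this read-out higher numbers stand for weaker inhibition of growth and lower numbers for stronger inhibition of growth. Compound 1 `O=C(Nc1cccc(-n2cc(-c3ccncc3)c(-c3ccc(Cl)c(O)c3)n2)c1)Nc1cccc(C(F)(F)F)c1` gives 962 nM, and compound 2 `COc1cc(-c2nn(-c3cccc(NC(=O)Nc4ccc(Cl)c(Cl)c4)c3)cc2-c2ccncc2)ccc1Cl` gives 691 nM. Compound 2 shows the lower of the two numbers, but its gap to compound 1 lies within the usual scatter of this assay, so the two compounds cannot be told apart on these data.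

Compound 3 `COc1cc(-c2nn(-c3cccc(NC(=O)Nc4cccc(C(F)(F)F)c4)c3)cc2-c2ccncc2)ccc1Cl` differs from compound 2 in a single place: 3-(trifluoromethyl)phenyl in place of 3,4-dichlorophenyl on an amide-type nitrogen. In other words, a 3-(trifluoromethyl)phenyl replaces a 3,4-dichlorophenyl on the amide-type nitrogen of the urea. Going by the values given here, no measured pair shows this exact exchange, so there is no directly comparable step to lean on. Since both measured compounds sit close together, the step from compound 2 to compound 3 is expected to be small, a 1.3-fold higher number from compound 2 to compound 3 (0.11 log units; within the scatter), with no clear direction beyond the scatter. Compound 3 is therefore estimated at 900 nM in this assay, within a range from 400 nM to 2000 nM.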

Compound 3, concentration for 50% growth inhibition: 306 nM
For compound 3 the middle estimate is 2.9-fold (0.47 log units) above the measured one; the whole stated range lies above it.
By their numbers in this assay, from the lowest: compound 3; then compounds 2 and 1 (each within the scatter of the next).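

In this assay, the group on the amide-type nitrogen of the urea now shows an effect that can be read: 3-(trifluoromethyl)phenyl in place of 3,4-dichlorophenyl gives a 2.3-fold lower number from compound 2 to compound 3 (0.35 log units; beyond the scatter), a modest step beyond the scatter. With that same 3-(trifluoromethyl)phenyl kept in place, methyl in place of hydrogen on an oxygen on an aromatic ring gives a 3.1-fold lower number from compound 1 to compound 3 (0.50 log units; beyond the scatter), so a second place on the molecule also moves the number, again modestly. Nothing measured here explains why either change has this result.

On these data alone, it remains open how a simple methyl group or an amine would compare with 3-(trifluoromethyl)phenyl on the amide-type nitrogen. Also open, as far as these compounds go, is whether ethyl in place of methyl on that oxygen would shift the number further.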